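Triazole-Linked Flavanone Series: Substituent Change on the Triazole Arm

The source may hold more compounds than are shown below. What is called first, only, known or untested is meant among the compounds shown, and "the series" means these compounds.

Measured so far:
compound 1, `COc1ccc([C@@H]2CC(=O)c3c(O)cc(OCc4cn(Cc5ccccc5C(F)(F)F)nn4)cc3O2)cc1O`, 12500 nM
compound 2, `COc1ccc([C@@H]2CC(=O)c3c(O)cc(OCc4cn(Cc5ccccc5C)nn4)cc3O2)cc1O`, 13100 nM

Both compounds share the same core and differ only on the aromatic carbon of the benzyl arm. In a functional assay on RAW264.7 cells (Mus musculus) for inhibition, read by Griess assay, with stated times of 2 h and 24 h (a higher number here means a weaker inhibitor, a lower number a stronger inhibitor), compound 1 gives the lowest of the two numbers, and its nearest neighbour is compound 2; the step of a 1.0-fold higher number from compound 1 to compound 2 (0.02 log units; within the scatter) is within the scatter, so the two values cannot be ordered.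

Compound 3, `COc1ccc([C@@H]2CC(=O)c3c(O)cc(OCc4cn(CCCO)nn4)cc3O2)cc1O`, has not been measured. Relative to compound 1 the change is 2-hydroxyethyl in place of 2-(trifluoromethyl)phenyl on a saturated chain carbon bound to an aromatic nitrogen. For the measured compounds named here, no measured step covers this change: the only step in hand, a 1.0-fold higher number from compound 1 to compound 2 (0.02 log units; within the scatter), swaps one aromatic substituent for another and leaves the benzyl arm in place, whereas here the whole 2-(trifluoromethyl)phenyl is replaced by 2-hydroxyethyl. With nothing directly comparable, the expectation for a 1.2-fold higher number from compound 1 to compound 3 (0.08 log units; within the scatter) is a step of no clear direction and not beyond the scatter, held with a wide range. Compound 3 is therefore estimated at 15000 nM, between 6000 nM and 40000 nM.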

Compound 3, half-maximal inhibitory concentration: 16700 nM
Estimate against measurement, compound 3: 1.1-fold (0.05 log units) below, within the range that was stated.
By their numbers in this assay, from the lowest: compounds 1, 2 and 3 (each within the scatter of the next).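

In this assay, 2-hydroxyethyl in place of 2-(trifluoromethyl)phenyl on a saturated chain carbon bound to an aromatic nitrogen gives a 1.3-fold higher number from compound 1 to compound 3 (0.13 log units; within the scatter) and, in place of 2-methylphenyl, gives a 1.3-fold higher number from compound 2 to compound 3 (0.11 log units; within the scatter) as the second step. The earlier pair changed only a substituent on the aromatic ring, whereas these steps remove the ring from the arm altogether and compound 3 still cannot be ordered against compound 1 or compound 2, so the ring is not shown to be needed for the numbers seen here. Nothing in hand explains this result.

On these data alone, whether an amine, a carboxylic acid or a longer chain on the triazole arm would give a step beyond the scatter stays open. No step shown here leaves the scatter, so how much this position can influence the read-out is also unknown.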